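Swapping a Urea for a Sulfonyl on the Ring Nitrogen

The compounds below may be only part of what the source reports. "The series", "measured", "known", "first", "only" and "open" are said of these compounds alone.

Compound 1, `Cn1nc(COc2ccc(F)c(F)c2)c2c1CCN(C(=O)Nc1ccc(Cl)cc1)C2`, gives 4600 nM in an assay on cells for inhibition of Pendrin (Mus musculus), read by fluorescence, with a stated time of 10 min; on this read-out higher numbers stand for weaker inhibition and lower numbers for stronger inhibition.
Compound 2, `CCOC(=O)c1nn(C)c2c1CN(C(=O)Nc1ccc(Cl)cc1)CC2`, gives > 10000 nM in this assay, which is a limit of the assay and not a number.
Compound 3, `Cn1nc(COc2cc(F)cc(F)c2)c2c1CCN(C(=O)NC1CCCCC1)C2`, gives > 10000 nM in this assay, again a limit rather than a number.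

Compound 3 therefore stands at the limit of this assay; two of the three values shown sit there, as the limit of > 10000 nM in this assay, at which 2 of the 3 values shown sit, records, and only compound 1 gives a measured number. The unmeasured compound 4, `Cn1nc(COc2cc(F)cc(F)c2)c2c1CCN(S(=O)(=O)c1ccc(Cl)cc1)C2`, differs from compound 3 in one place: (4-chlorophenyl)sulfonyl in place of cyclohexylcarbamoyl on an amine nitrogen in a ring. Going by the values given here, the only step measured so far, an at least 2.1-fold higher number from compound 1 to compound 2 (0.33 log units; beyond the scatter), changes a group on an aromatic carbon and not the group on the ring nitrogen, so it gives no direct guide to this change. With compound 3 already at the limit, no step beyond the scatter can be read in either direction. Compound 4 is expected to stay near the limit, so the estimated step is a number no higher from compound 3 to compound 4 (the limit leaves the size open). The estimate for compound 4 is 10000 nM, expected to fall between 3000 nM and 30000 nM.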

Compound 4, half-maximal inhibitory concentration: > 10000 nM
Compound 4: no number, only a limit (the forecaster's own chance of this, stated with the estimate: 55%); the middle value lies on the limit itself.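

Compound 3 and compound 4 both give only a limit in this assay, not a number, so no step can be read between them: the limit of > 10000 nM in this assay, at which 3 of the 4 values shown sit.

The compounds shown leave open whether (4-chlorophenyl)sulfonyl in place of cyclohexylcarbamoyl on the amine nitrogen strengthens inhibition, weakens it, or leaves it unchanged.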